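The source may hold more compounds than are shown below. What is called first, only, known or untested is meant among the compounds shown, and "the series" means these compounds.

Compound 1 `Fc1ccc(Cn2cc(CCCOc3cccc4cccnc34)nn2)cc1F` and compound 2 `Clc1cc(Cl)c(Cn2cc(CCCOc3cccc4cccnc34)nn2)c(Cl)c1` share a core and differ only in the aryl group on a saturated chain carbon bound to an aromatic nitrogen. In a functional assay on PC-3 cells (Homo sapiens) for inhibition, read by sulforhodamine B assay, with a stated time of 48 h (on this read-out higher numbers stand for weaker inhibition of growth and lower numbers for stronger inhibition of growth), compound 1 gives 6.6 ug/mL, while compound 2 gives 2.8 ug/mL. Going by the values given here, the step of a 2.4-fold lower number from compound 1 to compound 2 (0.37 log units; beyond the scatter) is the only measured step so far, and it leaves compound 2 with the lowest of the two numbers, compound 1 being its nearest neighbour.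

Compound 3 `Clc1ccc(Br)cc1Cn1cc(CCCOc2cccc3cccnc23)nn1` has not yet been measured in this assay. It differs from compound 2 in one place: 5-bromo-2-chlorophenyl in place of 2,4,6-trichlorophenyl on a saturated chain carbon bound to an aromatic nitrogen. Among the compounds with values here, the one measured step bears on this change only loosely: it too exchanged one halogenated phenyl group for another at the same place, and it was modest. No measurement shows directly how a 5-bromo-2-chlorophenyl group compares with a 2,4,6-trichlorophenyl group, so the expected step of a 1.3-fold higher number from compound 2 to compound 3 (0.10 log units; within the scatter) is small, of uncertain direction, and may well stay within the scatter. Compound 3 is therefore estimated to give about 3.5 ug/mL in this assay, within a range from 1.4 ug/mL to 9 ug/mL.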

Compound 3, concentration for 50% growth inhibition: 8.2 ug/mL
The estimate for compound 3 lay 2.3-fold (0.37 log units) below the measured number; measured number inside the range.
By their numbers in this assay, from the lowest: compound 2; then compounds 1 and 3 (each within the scatter of the next).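

In this assay, the step of a 2.9-fold higher number from compound 2 to compound 3 (0.47 log units; beyond the scatter) shows that exchanging one halogenated phenyl group for another at this place can also raise the number beyond the scatter, so the fall seen earlier does not carry over to every such exchange. The step of a 1.2-fold higher number from compound 1 to compound 3 (0.09 log units; within the scatter) stays within the scatter, so 3,4-difluorophenyl and 5-bromo-2-chlorophenyl cannot be told apart here, and among these three compounds only the 2,4,6-trichlorophenyl group of compound 2 stands apart from the others; chlorine or bromine in place of fluorine does not by itself go with a lower number, and compound 3 is the case against it. Nothing available here accounts for these differences.

The compounds shown leave open whether the lower number of compound 2 depends on the number of chlorine atoms or on where they sit, since each of the three aryl groups differs from the others in both. They also leave open how a phenyl group with no halogen, or one carrying a methoxy group, an amine or a carboxylic acid, would compare at this place.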